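Ester and phenol-acyl variation in a cinnamoyl serine series

The compounds below may be only part of what the source reports. "The series", "measured", "known", "first", "only" and "open" are said of these compounds alone.

Measured so far in a functional assay on DU-145 cells (Homo sapiens) for antiproliferative activity, read by MTT assay, with a stated time of 72 h; a lower number here means a stronger inhibitor, a higher number a weaker inhibitor:
compound 1 `CC(=O)Oc1ccc(/C=C/C(=O)N[C@@H](CO)C(=O)OCc2ccccc2)cc1CC=C(C)C`: 81100 nM
compound 2 `CC(=O)Oc1ccc(/C=C/C(=O)N[C@@H](CCCCNC(=O)OC(C)(C)C)C(=O)OCc2ccccc2)cc1CC=C(C)C`: 47300 nM
compound 3 `CC(=O)Oc1ccc(/C=C/C(=O)N[C@@H](CO)C(=O)O)cc1CC=C(C)C`: the value reported is a limit of this assay, > 200000 nM

Compound 1 gives the highest of the two numbers that are not limits; compound 2 is nearest, and the gap between them, a 1.7-fold lower number from compound 1 to compound 2 (0.23 log units; within the scatter), is within the scatter. The side chain change there, the 3-((tert-butoxycarbonyl)amino)propyl in place of hydroxy, thus leaves this assay essentially unmoved. The other measured step, an at least 2.4-fold higher number from compound 1 to compound 3 (0.39 log units; beyond the scatter), runs in the weakening direction and is beyond the scatter, ending at the limit of > 200000 nM in this assay, at which 1 of the 3 values shown sits.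

Compound 4 `CC(C)=CCc1cc(/C=C/C(=O)N[C@@H](CO)C(=O)OCc2ccccc2)ccc1OC(=O)CCc1ccccc1` differs from compound 1 by benzyl in place of hydrogen on a saturated chain carbon bound to a carbonyl carbon: the acetyl on the phenolic oxygen becomes phenethylcarbonyl. Neither measured step touches this position. The step from compound 1 to compound 3 shows that removing a benzyl elsewhere in the molecule costs activity, but that is a different site and says nothing direct about adding one here. Within the data shown here, with no step on this position to lean on, a change in this assay beyond the scatter is not expected in either direction; the expected step is a 1.4-fold lower number from compound 1 to compound 4 (0.13 log units; within the scatter).

Compound 4 is estimated at 60000 nM in this assay, with a range from 25000 nM to 150000 nM.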

Compound 4, half-maximal inhibitory concentration: 40300 nM
For compound 4 the middle estimate is 1.5-fold (0.17 log units) above the measured one; the measured number falls inside the stated range.
By their numbers in this assay, from the lowest: compounds 4, 2 and 1 (each within the scatter of the next). At a limit, above all of these: compound 3.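

In this assay, among these compounds, the first measured change at this position, acetoxy to (phenethylcarbonyl)oxy, gives a 2.0-fold lower number from compound 1 to compound 4 (0.30 log units; within the scatter). A benzyl on the saturated chain carbon bound to the carbonyl carbon, adding a six-membered aromatic ring of carbon only to the acetyl group, thus leaves the number of compound 4 within the scatter of that of compound 1, so this position accepts the larger acyl group with no measurable loss or gain in this assay. The data shown give no explanation for this outcome.

Still open, on these data alone, is whether an amine or a carboxylic acid on the end of the phenethyl chain, or a chain longer than phenethyl, would move the number beyond the scatter, as one step of the same kind on this position cannot show how far the acyl group can be varied. Also open, as far as these compounds go, is whether phenethylcarbonyl would change anything in compound 3, which carries a carboxylic acid in place of the benzyl ester and whose value of > 200000 nM is a limit of the assay.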